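A few compounds are considered here, and "the series" means these few. Any claim that something is new, unique, unknown or untested is made for them only; others in the source may bear on it.

Three measured compounds and one still unmeasured share a single core. In a functional assay on cells (T-cell, Homo sapiens) for inhibition (a higher number here means a weaker inhibitor, a lower number a stronger inhibitor), compound 1 `COc1ccc(-c2cnc3nc(N)nc(N4CCN(C(=O)c5ccccc5)CC4)c3n2)cc1OC` gives 400 nM, the lowest of the two numbers recorded there. Compound 3 `CCOc1ccc(-c2cnc3nc(N)nc(OC(C)C)c3n2)cc1` gives 10000 nM in this assay, a gap from compound 1 that lies beyond the usual scatter. Compound 2 `CCOc1nc(N)nc2ncc(-c3ccc(C#N)cc3)nc12` reaches only a limit of this assay, > 10000 nM, and the limit of > 10000 nM in this assay, at which 1 of the 3 values shown sits, marks the point where one of the three values sits.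

Compound 4 `COc1ccc(-c2cnc3nc(N)nc(N4CCN(c5ccccc5)CC4)c3n2)cc1OC` differs from compound 1 in one place: phenyl in place of benzoyl on an amine nitrogen in a ring. The benzoyl that leaves carries one hydrogen-bond acceptor and one double bond outside aromatic rings; the phenyl that enters carries neither. Among the compounds with values here, no measured pair in this set makes the same exchange, so the size of the step can be judged from compound 1 alone. For compound 4 the estimate in this assay is 700 nM, with a range from 150 nM to 3000 nM. The step of a 1.8-fold higher number from compound 1 to compound 4 (0.24 log units; within the scatter) is therefore expected to be modest, most likely within the scatter, leaning toward a weaker inhibitor.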

Compound 4, half-maximal inhibitory concentration: 400 nM
Compound 4: the middle estimate sits 1.8-fold (0.24 log units) above what was measured, within the range that was stated.
By their numbers in this assay, from the lowest: compounds 1 and 4 (each within the scatter of the next); then compound 3.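

In this assay, within the data shown here, putting phenyl in place of benzoyl on the amine nitrogen in the ring gives no change at the digits printed from compound 1 to compound 4 (within the scatter), the first step in this set that can be read between compounds differing in one place. At this position, then, the hydrogen-bond acceptor and the double bond outside aromatic rings that benzoyl carries can go without a change in the number beyond the scatter, as long as a six-membered aromatic ring of carbon only remains. Nothing in the available evidence explains this result.

The compounds shown leave open whether that aromatic ring is needed at all, which a cyclohexyl or a methyl group on the same nitrogen would test. They also leave open whether a longer link, as in benzyl, or a substituted phenyl, such as one carrying a carboxylic acid, would shift the number.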